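Methyl on an aromatic carbon, a second time in the series

A few compounds are considered here, and "the series" means these few. Any claim that something is new, unique, unknown or untested is made for them only; others in the source may bear on it.

Measured so far:
compound 1, `Cn1c(-c2ccc(NC(=O)CSc3nc4ccccc4o3)cc2)nc(-c2ccccc2)c1-c1ccccc1`: 56.2% in a functional assay on HT-29 cells (Homo sapiens) for cytotoxicity, read by MTT assay, with a stated time of 24 h, tested at 16 ug/mL; on this read-out lower numbers stand for a weaker effect and higher numbers for a stronger effect at the one concentration tested
compound 2, `Cc1ccc2oc(SCC(=O)Nc3ccc(-c4nc(-c5ccccc5)c(-c5ccccc5)n4C)cc3)nc2c1`: 37.7% in this assay
compound 3, `Cn1c(-c2ccc(NC(=O)CN3CCN(Cc4ccccc4)CC3)cc2)nc(-c2ccccc2)c1-c1ccccc1`: 37% in this assay

Compound 2 differs from compound 1 by methyl in place of hydrogen on an aromatic carbon. That step gave a number 18.5 percentage points lower from compound 1 to compound 2 (beyond the scatter). Compound 3 carries a different core from compound 1; the difference between the two cores is not broken down here. Compound 3 and compound 2 give numbers within the scatter of each other, while compound 1 stands beyond the scatter above compound 3.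

The unmeasured compound 4, `Cc1ccc(CN2CCN(CC(=O)Nc3ccc(-c4nc(-c5ccccc5)c(-c5ccccc5)n4C)cc3)CC2)cc1`, differs from compound 3 by methyl in place of hydrogen on an aromatic carbon. This is the same kind of change as the step from compound 1 to compound 2, but not the same: there the aromatic carbon is part of a fused or bridged system of two rings, meta to a fused ring and para to a fused ring; here it sits on a six-membered aromatic ring of carbon only, para to a large group.

For the measured compounds named here, only one measured instance of the change exists, on another core, so the expectation rests on a single step. The expected step is a number 9 percentage points lower from compound 3 to compound 4 (within the scatter), resting on a number 18.5 percentage points lower from compound 1 to compound 2 (beyond the scatter), with wide bounds because compound 3 starts from 37% and the place of the change differs. Compound 4 is expected to give 28% in this assay, estimated between 12% and 46%.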

Compound 4, a percentage reported as activity, at one concentration (the size of the read-out at that concentration, not a potency): 30.6%
Beside the measured number, compound 4's estimate is 2.6 percentage points below it; measured number inside the range.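

On the benzyl group of compound 3, methyl in place of hydrogen gives a number 6.4 percentage points lower from compound 3 to compound 4 (within the scatter) in this assay and so leaves no change on this core that can be separated from the scatter. The step on the other core cannot be told apart from this one: the same change on two cores in this assay, a number 18.5 percentage points lower (beyond the scatter) from compound 1 to compound 2 and a number 6.4 percentage points lower (within the scatter) from compound 3 to compound 4, 12.1 percentage points apart, within the scatter of two such steps

The two steps therefore give no sign that the core alters the outcome of this change, and both point to a lower number, but they do not show that the step has one common size across cores. Only two instances exist, one beyond the scatter and one within it, and the methyl sits on a different kind of ring system in each, so core and place of the change cannot be separated.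

The compounds shown leave open whether other groups at this aromatic carbon, such as fluorine, a methoxy group or a carboxylic acid, would move the number beyond the scatter on either core. Also open, as far as these compounds go, is how an amine or a longer chain in place of the methyl would read, and whether any substituent on these rings raises the number rather than lowers it.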